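Ether swap on the shared core: cyclopentyl to a heteroaromatic chain

The source may hold more compounds than are shown below. What is called first, only, known or untested is meant among the compounds shown, and "the series" means these compounds.

Compound 1 `Cc1nn(-c2ncnc3nc[nH]c23)c2c1C(OC1CCCC1)CC(=O)N2`: 2 nM
Compound 2 `Cc1nn(-c2ncnc3nc[nH]c23)c2c1C(OCc1ccc(C#N)cc1)CC(=O)N2`: 4 nM

In a functional assay on HEK293 cells for agonist activity at G-protein coupled receptor 39 (Homo sapiens), read by scintillation proximity assay and inositol phosphate accumulation, with a stated time of 75 min, in the presence of a further agent that is not named here (a lower number here means that less compound is needed, a higher number that more compound is needed for the effect), compound 1 gives the lowest of the two numbers; its nearest neighbour is compound 2, at a 2.0-fold higher number from compound 1 to compound 2 (0.30 log units; within the scatter). Compound 3 `Cc1nn(-c2ncnc3nc[nH]c23)c2c1C(OCCn1nccc1C)CC(=O)N2` differs from compound 1 by a group of 8 heavy atoms (6 carbon, 2 nitrogen; one five-membered aromatic ring with 2 hetero atoms) in place of a group of 5 heavy atoms (5 carbon; one five-membered non-aromatic ring of carbon only), on an oxygen on a saturated carbon. Among the measured compounds shown here, the only measured step at this oxygen, a 2.0-fold higher number from compound 1 to compound 2 (0.30 log units; within the scatter), stayed within the scatter, so the account expects no step beyond the scatter here either. Compound 3 is therefore estimated at 3 nM, within 1 nM to 10 nM. The expected step is a 1.5-fold higher number from compound 1 to compound 3 (0.18 log units; within the scatter).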

Compound 3, half-maximal effective concentration: 10 nM
Beside the measured number, compound 3's estimate is 3.3-fold (0.52 log units) below it; low and high end bracket the measured number.
By their numbers in this assay, from the lowest: compounds 1 and 2 (each within the scatter of the next); then compound 3.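

In this assay, among the compounds shown here, this oxygen turns out to be less permissive than the first pair suggested: the group with the five-membered aromatic ring with 2 hetero atoms gives the first step here beyond the scatter (a 5.0-fold higher number from compound 1 to compound 3 (0.70 log units; beyond the scatter)). The change from the 4-cyanophenyl to the (5-methyl-1H-pyrazol-1-yl)methyl end of the chain also lies beyond the scatter (a 2.5-fold higher number from compound 2 to compound 3 (0.40 log units; beyond the scatter)), so the group on this oxygen can move the number, though modestly. Nothing available accounts for this shift. The compounds shown leave open whether the aromatic ring or its methyl group matters here, and how a longer chain or an amine in its place would read.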